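The source may report more compounds than this note shows. Statements on the series, on what has been measured and on what is new or still open speak of the compounds shown alone.

Measured to date:
compound 1 `CCCCCCCCCCCC(=O)OC[C@H](CSC[C@@H](N)C(=O)N[C@@H](C)CO)OC(=O)CCCCCCCCCCC` gives 1560 nM
compound 2 `CCCCCCCCCCCC(=O)OC[C@H](CSC[C@@H](N)C(=O)NCCCS(=O)(=O)O)OC(=O)CCCCCCCCCCC` gives 5560 nM
compound 3 `CCCCCCCCCCCC(=O)OC[C@H](CSC[C@@H](N)C(=O)NC(CC)COC)OC(=O)CCCCCCCCCCC` gives 71.8 nM

All three share a core and differ only on an amide-type nitrogen, read out in an assay on HEK293 cells for agonist activity at Toll-like receptor 2 (Homo sapiens); a higher number here means that more compound is needed for the effect, a lower number that less compound is needed. Compound 1 stands second highest of the three numbers: compound 2 lies a 3.6-fold higher number from compound 1 to compound 2 (0.55 log units; beyond the scatter) away, compound 3 is the furthest, at a 22-fold lower number from compound 1 to compound 3 (1.34 log units; beyond the scatter). Between them, a 77-fold lower number from compound 2 to compound 3 (1.89 log units; beyond the scatter).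

Compound 4 `CCCCCCCCCCCC(=O)OC[C@H](CSC[C@@H](N)C(=O)N[C@@H](CC)COCC(=O)O)OC(=O)CCCCCCCCCCC` is not yet measured. Against compound 1 the change is 1-((carboxymethoxy)methyl)propyl in place of 1-(hydroxymethyl)ethyl on an amide-type nitrogen.

Among the measured compounds shown here, two measured steps bear on this. For the measured compounds named here, the 1-((carboxymethoxy)methyl)propyl group carries the propyl and ether of the 1-(methoxymethyl)propyl group of compound 3, whose step was large and downward, but also a carboxy group, and the only measured change adding an acid group, to 3-sulfopropyl in compound 2, went modestly upward. The two pull against each other, so only a modest net step is expected, a 2.2-fold lower number from compound 1 to compound 4 (0.35 log units; beyond the scatter). For compound 4 the expected value is 700 nM, with a range from 150 nM to 4000 nM.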

Compound 4, half-maximal effective concentration: 6500 nM
Compound 4: middle estimate off by 9.3-fold (0.97 log units), on the low side; measured number outside the range, above it.
By their numbers in this assay, from the lowest: compound 3; then compound 1; then compounds 2 and 4 (each within the scatter of the next).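

In this assay, the propyl and ether carried over from the 1-(methoxymethyl)propyl group do not preserve the low number of compound 3 once a carboxy group is present (a 91-fold higher number from compound 3 to compound 4 (1.96 log units; beyond the scatter)). The full change from 1-(hydroxymethyl)ethyl on the amide-type nitrogen ends upward (a 4.2-fold higher number from compound 1 to compound 4 (0.62 log units; beyond the scatter)), while the two acid-bearing groups cannot be told apart (a 1.2-fold higher number from compound 2 to compound 4 (0.07 log units; within the scatter)), so among these four compounds both sit at the high end despite their different chains. No available measurement explains why the carboxy group outweighs the rest of the substituent.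

Open, on these data alone, is whether a primary amine or a methyl ester in place of the carboxy group would stay close to compound 3 or to compound 4. Also open, as far as these compounds go, is what the propyl and the ether each contribute alone.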